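The compounds below may be only part of what the source reports. "The series", "measured", "known", "first", "only" and "open" are said of these compounds alone.

Measured compounds in the series:

compound 1, `C=CC1=C(C(=O)Nc2ccccc2OC)C(c2ccc(F)cc2)OC1`, > 100000 nM
compound 2, `C=CC1=C(C(=O)Nc2ccccc2OC)C(c2ccc(Cl)c(Cl)c2)OC1`, > 100000 nM
compound 3, `C=CC1=C(C(=O)NCc2ccccc2)C(c2ccc(F)cc2)OC1`, > 100000 nM

The read-out is a functional assay on HeLa cells (Homo sapiens) for cytotoxicity, read by MTT assay, with a stated time of 24 h; on this read-out lower numbers stand for stronger inhibition and higher numbers for weaker inhibition. In this assay compound 1 reaches only a limit, > 100000 nM. Compound 2 likewise reaches only a limit, > 100000 nM. Compound 3 too reaches only a limit, > 100000 nM. Each of these values is a limit of the assay and not a number; the limit of > 100000 nM in this assay, at which 3 of the 3 values shown sit, covers all three.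

Compound 2 arises from compound 1 by 3,4-dichlorophenyl in place of 4-fluorophenyl on a saturated ring carbon; the step that the two limits leave unreadable from compound 1 to compound 2 cannot be sized, as both ends are limits. Compound 3 arises from compound 1 by benzyl in place of 2-methoxyphenyl on an amide-type nitrogen; here too the step that the two limits leave unreadable from compound 1 to compound 3 is unreadable.

Compound 4, `C=CC1=C(C(=O)NCc2ccccc2)C(c2ccc(Cl)c(Cl)c2)OC1`, is not yet measured in this assay. It arises from compound 3 by 3,4-dichlorophenyl in place of 4-fluorophenyl on a saturated ring carbon. This is the same change as that from compound 1 to compound 2, at the same place on the shared core, the two cores differing only by benzyl in place of 2-methoxyphenyl on an amide-type nitrogen.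

Among the measured compounds shown here, with every value so far sitting at the limit, the step from compound 3 to compound 4 is expected to be roughly flat, a step that the limit leaves unreadable from compound 3 to compound 4, resting on the unreadable step that the two limits leave unreadable from compound 1 to compound 2 and the limit of compound 3, > 100000 nM. Compound 4 is therefore estimated at 150000 nM in this assay, most likely again reported only as a limit.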

Compound 4, half-maximal inhibitory concentration: > 100000 nM
Compound 4: only a limit was reported (the forecaster's own chance of this, stated with the estimate: 85%); the middle value lies beyond the limit too.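

No new step can be read among compound 1, compound 2, compound 3 and compound 4, since each value is a limit and not a number: the limit of > 100000 nM in this assay, at which 4 of the 4 values shown sit.

The compounds shown leave open whether 3,4-dichlorophenyl in place of 4-fluorophenyl, or benzyl in place of 2-methoxyphenyl, changes anything in this assay, as none of them gives a value that can be sized.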